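Replacing a thiophene by a methylpyrazole on the benzyl arm

A few compounds are considered here, and "the series" means these few. Any claim that something is new, unique, unknown or untested is made for them only; others in the source may bear on it.

The three measured compounds share a urea core carrying a cycloheptyl group on one nitrogen. Compound 1 `Cc1cc(C)c(NC(=O)N(Cc2ccc(-c3ccccc3)nc2)C2CCCCCC2)c(C)c1` gives 260 nM in an assay on microsomes from intestine for inhibition of acyl-CoA:cholesterol acyltransferase (Oryctolagus cuniculus); on this read-out higher numbers stand for weaker inhibition and lower numbers for stronger inhibition. Compound 2 `O=C(Nc1c(F)cc(F)cc1F)N(Cc1ccc(-c2ccsc2)cc1)C1CCCCCC1` gives 23 nM in this assay, and compound 3 `Cc1cc(C)c(NC(=O)N(Cc2ccc(-c3ccsc3)cc2)C2CCCCCC2)c(C)c1` gives 19 nM. Compound 3 thus holds the lowest of the three numbers; its step from compound 2 is a 1.2-fold lower number from compound 2 to compound 3 (0.08 log units; within the scatter), while compound 1 sits well apart from both. Compound 4 `Cc1cc(C)c(NC(=O)N(Cc2ccc(-c3ccnn3C)cc2)C2CCCCCC2)c(C)c1` differs from compound 3 in one place: 1-methyl-1H-pyrazol-5-yl in place of thiophen-3-yl on an aromatic carbon. Within the data shown here, no measured pair isolates such a change on the benzyl arm; the step from compound 2 to compound 3 concerns the other nitrogen, and compound 1 differs from compound 3 in more than one place, so it cannot be weighed alone. Without a direct precedent, compound 4 is expected to lose some potency, with a step of a 2.6-fold higher number from compound 3 to compound 4 (0.42 log units; beyond the scatter) beyond the scatter in this assay. The estimate for compound 4 is 50 nM, within 15 nM to 200 nM.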

Compound 4, half-maximal inhibitory concentration: 24 nM
Estimate against measurement, compound 4: 2.1-fold (0.32 log units) above; measured number inside the range.
By their numbers in this assay, from the lowest: compounds 3, 2 and 4 (each within the scatter of the next); then compound 1.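

With a 1.3-fold higher number from compound 3 to compound 4 (0.10 log units; within the scatter) in this assay, the place para to a large group on the six-membered aromatic ring of carbon only accepts 1-methyl-1H-pyrazol-5-yl as readily as thiophen-3-yl. Among these compounds, this is the first single change read on the benzyl arm, and it shows that the sulfur of the thiophen-3-yl can give way to a ring with 2 hetero atoms and 2 hydrogen-bond acceptors without a step beyond the scatter. Nothing available bears on the reason for this result.

Going by these compounds, it remains open how far this tolerance extends on the benzyl arm, for example to a morpholine, an aminomethyl group or a carboxylic acid. Also open, on these data alone, is whether 1-methyl-1H-pyrazol-5-yl behaves the same way with 2,4,6-trifluorophenyl on the other nitrogen.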